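Tolerated Concentrations Across a Set of Substituted Benzyl Analogues

This account rests on a few compounds, and the source may have more. Where it says the series, first, only, none or still open, it means among the compounds named here.

Compound 3 `Cn1cc(SCc2nnc(SCc3c(Cl)cccc3Cl)n2-c2c(Cl)cccc2Cl)c2ccccc21` carries the shared core of this series, and in a toxicity assay on HEK-293T cells (Homo sapiens) for cytotoxicity, read by CCK-8 assay, with a stated time of 48 h (a higher number here means that more compound is tolerated, a lower number that less compound is tolerated), compound 3 gives > 100000 nM, which is a limit of the assay rather than a number. Compound 1 `Cn1cc(SCc2nnc(SCc3ccccc3OC(F)(F)F)n2-c2c(Cl)cccc2Cl)c2ccccc21` stands in the same place: in this assay compound 1 gives > 100000 nM, again a limit. Compound 2 `Cn1cc(SCc2nnc(SCc3cccc(Cl)c3Cl)n2-c2c(Cl)cccc2Cl)c2ccccc21` follows suit, since in this assay compound 2 gives > 100000 nM, also a limit. With every value a limit, a step that the two limits leave unreadable from compound 1 to compound 2, a step that the two limits leave unreadable from compound 1 to compound 3 and a step that the two limits leave unreadable from compound 2 to compound 3 cannot be sized; all that the three values share is the limit of > 100000 nM in this assay, at which 3 of the 3 values shown sit.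

Compound 4 `Cn1cc(SCc2nnc(SCc3ccc(Cl)c(F)c3)n2-c2c(Cl)cccc2Cl)c2ccccc21` has not yet been measured in this assay. It differs from compound 3 in one place: 4-chloro-3-fluorophenyl in place of 2,6-dichlorophenyl on a saturated chain carbon bound to a sulfur. The measured steps that bear on this change are the three exchanges of a substituted phenyl on the same saturated chain carbon bound to a sulfur, and none of them moved any compound off the limit. The step expected is a number no higher from compound 3 to compound 4 (the limit leaves the size open), which is to say none beyond the scatter. The estimate for compound 4 in this assay is 100000 nM, with a range from 50000 nM to 300000 nM, and it is expected that the assay will most likely again report only a limit.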

Compound 4, half-maximal cytotoxic concentration: > 100000 nM
Compound 4 gave a limit, no number (the forecaster's own chance of this, stated with the estimate: 85%); the middle value sits exactly at the limit.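

In this assay compound 4 gives > 100000 nM, again a limit. Its steps from compound 1, compound 2 and compound 3 cannot be read, and all the values share one limit: the limit of > 100000 nM in this assay, at which 4 of the 4 values shown sit.

The compounds shown leave open how much of each compound is actually tolerated, and whether exchanging the substituted phenyl on a saturated chain carbon bound to a sulfur changes that at all.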